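The source may report more compounds than this note shows. Statements on the series, on what has been measured and on what is new or still open speak of the compounds shown alone.

Measured compounds in a functional assay on MCF7 cells (Homo sapiens) for cytotoxicity, read by MTT assay, with a stated time of 72 h; on this read-out lower numbers stand for stronger inhibition and higher numbers for weaker inhibition:
compound 1 `COc1cccc(/C=C2\CCC/C(=C\c3cccc(Cl)c3)C2=O)c1OC` gives 12000 nM
compound 2 `COc1cccc(/C=C2\CCC/C(=C\c3ccc(Cl)cc3)C2=O)c1OC` gives 10300 nM
compound 3 `COc1cccc(/C=C2\CCC/C(=C\c3cccc(Br)c3)C2=O)c1OC` gives 11700 nM

Compound 2 has the lowest of the three numbers in this assay, but its nearest neighbour is compound 3 at a 1.1-fold higher number from compound 2 to compound 3 (0.06 log units; within the scatter) and the furthest is compound 1 at a 1.2-fold lower number from compound 1 to compound 2 (0.07 log units; within the scatter), so all three stand within the scatter of one another and no order among them can be read from these values.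

Compound 4 `COc1cccc(/C=C2\CCC/C(=C\c3ccc(O)c(Cl)c3)C2=O)c1OC` differs from compound 2 in one place: 3-chloro-4-hydroxyphenyl in place of 4-chlorophenyl on a double-bonded chain carbon bound to a double-bonded ring carbon.

Among the measured compounds shown here, the steps that bear on this change are those that swap one halogenated phenyl for another at the same place, a 1.2-fold lower number from compound 1 to compound 2 (0.07 log units; within the scatter) and a 1.1-fold higher number from compound 2 to compound 3 (0.06 log units; within the scatter), and also a 1.0-fold lower number from compound 1 to compound 3 (0.01 log units; within the scatter); each is within the scatter. For the measured compounds named here, none of the measured compounds carries a hydroxyl, so the data give no step for adding one. From the three halogen variants alone the expectation for this assay is no step beyond the scatter.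

Compound 4 is therefore expected to give about 10000 nM, with a range from 4000 nM to 25000 nM, which amounts to an expected step of a 1.0-fold lower number from compound 2 to compound 4 (0.01 log units; within the scatter).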

Compound 4, half-maximal inhibitory concentration: 16400 nM
Estimate against measurement, compound 4: 1.6-fold (0.21 log units) below, and the stated range covers the measured number.
By their numbers in this assay, from the lowest: compounds 2, 3, 1 and 4 (each within the scatter of the next).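

In this assay compound 4, the only one here with a hydroxy group, stays within the scatter of all three halogen variants, with a 1.6-fold higher number from compound 2 to compound 4 (0.20 log units; within the scatter) and a 1.4-fold higher number from compound 3 to compound 4 (0.15 log units; within the scatter) and a 1.4-fold higher number from compound 1 to compound 4 (0.14 log units; within the scatter) as its steps. The last step is the most direct reading, as it is simply hydroxy in place of hydrogen on an aromatic carbon. At this place, then, a phenyl carrying a hydrogen-bond donor and acceptor gives a number that the halogen-only phenyls cannot be told apart from. No measurement shown here offers an explanation for this result.

From the compounds shown here alone, whether an amine or a carboxylic acid in place of the hydroxy would give a step beyond the scatter remains open. So does whether a methoxy group there would.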